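The source may report more compounds than this note shows. Statements on the series, on what has been measured and on what is new or still open speak of the compounds shown alone.

Working notes on the series. In a functional assay on TSGH 9201 cells (Homo sapiens) for cytotoxicity (on this read-out lower numbers stand for stronger inhibition and higher numbers for weaker inhibition), compound 1 (`COc1ccc(S(=O)(=O)N2CCc3cccc(NC(=O)c4ccc([N+](=O)[O-])cc4)c32)cc1`) gives 116 nM and compound 2 (`COc1ccc(S(=O)(=O)N2CCc3cccc(NC(C)=O)c32)cc1`) gives 103 nM on the shared core. Compound 2 holds the lower of the two numbers only nominally, and the pair cannot be separated (a 1.1-fold lower number from compound 1 to compound 2 (0.05 log units; within the scatter)). The next change leads to compound 3 (`COc1ccc(S(=O)(=O)N2CCc3cccc(NC(=O)c4ccco4)c32)cc1`), which has furan-2-yl in place of methyl on a carbonyl carbon. Among the measured compounds shown here, only one measured step bears on this carbonyl carbon, namely the exchange of 4-nitrophenyl for methyl (a 1.1-fold lower number from compound 1 to compound 2 (0.05 log units; within the scatter)). That step is small, so the presence of a ring on this carbon has so far made no visible difference in this assay (a single pair only). For the measured compounds named here, no measured compound carries furan-2-yl, and the estimate therefore rests on that one step and stays wide on both sides. The estimated change (a 1.3-fold lower number from compound 2 to compound 3 (0.11 log units; within the scatter)) is expected to stay within the scatter, with no firm direction, although a slightly lower number is allowed for. Compound 3 is expected at 80 nM (estimated range from 25 nM to 250 nM).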

Compound 3, half-maximal inhibitory concentration: 11.1 nM
The estimate for compound 3 lay 7.2-fold (0.86 log units) above the measured number; the whole stated range lies above it.
By their numbers in this assay, from the lowest: compound 3; then compounds 2 and 1 (each within the scatter of the next).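

In this assay, the carbonyl carbon of the amide is clearly sensitive to its substituent, which the first pair could not show: furan-2-yl separates beyond the scatter from methyl (a 9.3-fold lower number from compound 2 to compound 3 (0.97 log units; beyond the scatter)) and from 4-nitrophenyl (a 10-fold lower number from compound 1 to compound 3 (1.02 log units; beyond the scatter)), even though those two groups stayed within the scatter of each other. Carrying a ring on this carbon is therefore not enough in itself, as compound 1 has a ring and still cannot be separated from compound 2, which has none; within these three compounds, the lower number goes with furan-2-yl alone. The data shown offer no independent measurement that could account for this difference.

On these data alone, it remains open whether the lower number depends on the ring oxygen, the five-membered ring or the absence of the nitro group, and thiophen-2-yl or unsubstituted phenyl on the same carbonyl carbon would begin to separate these readings. As far as these compounds go, it is equally open how far the carbon tolerates other kinds of group, such as an aminomethyl group or a longer alkyl chain.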